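The source may report more compounds than this note shows. Statements on the series, on what has been measured and on what is new or still open speak of the compounds shown alone.

Compound 1 `Cc1ccc2c(NCc3ccco3)nc(NC(C)C)nc2c1` and compound 3 `COc1ccc2c(NCc3ccco3)nc(NC(C)C)nc2c1` share one core; in a physicochemical assay for permeability, using PAMPA, at pH 4 (on this read-out higher numbers stand for higher permeability and lower numbers for lower permeability), compound 1 gives 67.2 10^-6 cm/s and compound 3 gives 59.2 10^-6 cm/s. The change between them is methoxy in place of methyl on an aromatic carbon, and it made a 1.1-fold lower number from compound 1 to compound 3 (0.06 log units; within the scatter). Compound 2 `Cc1cccc2nc(NC(C)C)nc(NCc3ccco3)c12` carries a core built from the same atoms joined differently; the difference between the two cores is not broken down here. In this assay compound 2 gives 45.9 10^-6 cm/s, within the scatter of compound 1 and compound 3. Compound 4 `COc1cccc2nc(NC(C)C)nc(NCc3ccco3)c12` is not yet measured and differs from compound 2 by methoxy in place of methyl on an aromatic carbon. This is the same kind of change as from compound 1 to compound 3, though the place differs: meta and para to a fused ring there, ortho and meta to a fused ring here. From compound 2 to compound 4 the expected step is a 1.1-fold lower number from compound 2 to compound 4 (0.04 log units; within the scatter), resting on the step from compound 1 to compound 3 being a 1.1-fold lower number from compound 1 to compound 3 (0.06 log units; within the scatter). For compound 4 the estimate is 42 10^-6 cm/s, between 25 10^-6 cm/s and 70 10^-6 cm/s.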

Compound 4, apparent permeability: 87 10^-6 cm/s
For compound 4 the middle estimate is 2.1-fold (0.32 log units) below the measured one; the whole stated range lies below it.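

In this assay methoxy in place of methyl gives a 1.9-fold higher number from compound 2 to compound 4 (0.28 log units; within the scatter), and the same change on the other core gave a 1.1-fold lower number from compound 1 to compound 3 (0.06 log units; within the scatter), so on both cores the change stays within the scatter. These two steps show neither that the change carries over unaltered nor that it behaves differently between the cores, and its place on the ring also differs between them. No available data bear on the cause of either step.

The compounds shown leave open how an amine or a carboxylic acid in place of the methoxy would read on either core. They also leave open whether any replacement at this aromatic carbon gives a step beyond the scatter.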